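Cytotoxicity notes: benzyl variation on the triazole nitrogen

The source may report more compounds than this note shows. Statements on the series, on what has been measured and on what is new or still open speak of the compounds shown alone.

Measured compounds in an ADME assay on MT4 cells (Homo sapiens) for cytotoxicity, read by MTT assay, with a stated time of 5 days; on this read-out higher numbers stand for lower toxicity in this test and lower numbers for higher toxicity in this test:
- compound 1 `Cc1cccc(Cn2cc(CNC(=O)c3cnc(Nc4ccc(C#N)cc4)cc3Oc3c(C)cc(C)cc3C)nn2)c1`; compound 1 gives 114000 nM
- compound 2 `Cc1cc(C)c(Oc2cc(Nc3ccc(C#N)cc3)ncc2C(=O)NCc2cn(CCC#N)nn2)c(C)c1`; compound 2 gives 40200 nM
- compound 3 `Cc1cc(C)c(Oc2cc(Nc3ccc(C#N)cc3)ncc2C(=O)NCc2cn(Cc3cccc(C#N)c3)nn2)c(C)c1`; compound 3 gives >= 129000 nM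

The value for compound 3 is a limit of this assay, not a number, as noted in the limit of >= 129000 nM in this assay, at which 1 of the 3 values shown sits. On the numbers shown, compound 3 therefore stands at the upper end of the series. The step of an at least 1.1-fold higher number from compound 1 to compound 3 (0.05 log units; that floor lies within the scatter) shows that trading methyl for cyano on the aromatic ring changed little. The step of an at least 3.2-fold higher number from compound 2 to compound 3 (0.50 log units; beyond the scatter) and the step of a 2.8-fold lower number from compound 1 to compound 2 (0.45 log units; beyond the scatter) show that the cyanomethyl chain of compound 2 sits clearly lower than either aryl-bearing analogue.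

Compound 4 `Cc1cc(C)c(Oc2cc(Nc3ccc(C#N)cc3)ncc2C(=O)NCc2cn(Cc3ccccc3C)nn2)c(C)c1` differs from compound 3 by 2-methylphenyl in place of 3-cyanophenyl on a saturated chain carbon bound to an aromatic nitrogen. The change keeps an aryl group on the saturated chain carbon bound to the aromatic nitrogen, so the relevant comparison is compound 1 with its 3-methylphenyl and its value 114000 nM, which sits within the scatter of compound 3. No step larger than the scatter is expected for compound 4 in this assay; the estimated step is an at least 1.1-fold lower number from compound 3 to compound 4 (0.04 log units; that floor lies within the scatter). Compound 4 is estimated at 115000 nM, with a range from 50000 nM to 260000 nM, and a fair chance that only a limit is reported.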

Compound 4, half-maximal cytotoxic concentration: >= 164000 nM
Compound 4 gave a limit, no number; the forecaster's own chance of this, stated with the estimate: 35%; middle value at least 1.4-fold (0.15 log units) away from the limit.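

In this assay compound 4 gives only a limit, not a number, and it shows that such a limit also occurs with no nitrile on the ring: the limit of >= 164000 nM in this assay, at which 1 of the 4 values shown sits.

The 2-methylphenyl group stays clear of the cyanomethyl chain, with an at least 4.0-fold higher number from compound 2 to compound 4 (0.61 log units; beyond the scatter), while the change from 3-methylphenyl gives only an at least 1.4-fold higher number from compound 1 to compound 4 (0.15 log units; that floor lies within the scatter). The step between compound 3 and compound 4 cannot be read.

On these data alone, how far the 3-cyanobenzyl and 2-methylbenzyl groups differ in this test therefore remains open. Also open, as far as these compounds go, is whether a ring carrying an amine or a carboxylic acid, or a longer chain in place of the benzyl group, would stay with the aryl analogues or fall towards compound 2.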